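Triazole esters of the shared core: compound 4

The compounds below may be only part of what the source reports. "The series", "measured", "known", "first", "only" and "open" are said of these compounds alone.

Going by the values given here, compound 1 `C#CCOC(=O)/C(C)=C/CC/C(C)=C/CC/C(C)=C/CC[C@@H]1[C@@]2(C)CCC(=O)C(C)(C)[C@H]2CC[C@@]1(C)O` is the only member of the set that gives a number in a functional assay on MDA-MB-231 cells (Homo sapiens) for antiproliferative activity, read by MTT assay, with a stated time of 48 h; a higher number here means a weaker inhibitor, a lower number a stronger inhibitor; in that assay compound 1 gives 114000 nM. Compound 2 `C/C(=C\CC/C(C)=C/CC[C@@H]1[C@@]2(C)CCC(=O)C(C)(C)[C@H]2CC[C@@]1(C)O)CC/C=C(\C)C(=O)OCc1cn(-c2ccccc2C)nn1` carries a 1-(2-methylphenyl)-1H-1,2,3-triazol-4-yl in place of the ethynyl. In this assay compound 2 reaches only a limit, > 150000 nM. Compound 3 `C/C(=C\CC/C(C)=C/CC[C@@H]1[C@@]2(C)CCC(=O)C(C)(C)[C@H]2CC[C@@]1(C)O)CC/C=C(\C)C(=O)OCc1cn(-c2ccccc2F)nn1` carries the 1-(2-fluorophenyl) analogue of the same triazole. In this assay compound 3 likewise reaches only a limit, > 150000 nM. The two measured steps from the ethynyl ester are therefore an at least 1.3-fold higher number from compound 1 to compound 2 (0.11 log units; that floor lies within the scatter) and an at least 1.3-fold higher number from compound 1 to compound 3 (0.11 log units; that floor lies within the scatter), and the step between the two triazoles is a step that the two limits leave unreadable from compound 2 to compound 3, since (the limit of > 150000 nM in this assay, at which 2 of the 3 values shown sit).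

Compound 4 `C/C(=C\CC/C(C)=C/CC[C@@H]1[C@@]2(C)CCC(=O)C(C)(C)[C@H]2CC[C@@]1(C)O)CC/C=C(\C)C(=O)OCc1cn(-c2cccc(O)c2)nn1` is the next member, differing from compound 1 as 1-(3-hydroxyphenyl)-1H-1,2,3-triazol-4-yl in place of ethynyl on a saturated chain carbon bound to an oxygen next to a carbonyl group. Both triazole steps that bear on it end at the limit, so the same outcome is expected here: compound 4 is expected to move by a 1.8-fold higher number from compound 1 to compound 4 (0.24 log units; within the scatter), toward a weaker inhibitor, with a fair chance that only a limit is reported. The estimate for compound 4 in this assay is 200000 nM, within 90000 nM to 450000 nM.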

Compound 4, half-maximal inhibitory concentration: 139000 nM
Estimate against measurement, compound 4: 1.4-fold (0.16 log units) above; low and high end bracket the measured number.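

In this assay compound 4 is the only triazole ester shown that gives a number and not a limit, so this position, a saturated chain carbon bound to an oxygen next to a carbonyl group, now has one readable triazole step. That step is a 1.2-fold higher number from compound 1 to compound 4 (0.09 log units; within the scatter) and so the exchange of ethynyl for 1-(3-hydroxyphenyl)-1H-1,2,3-triazol-4-yl, with its two aromatic rings, does not separate compound 4 from compound 1 in this assay. Against the other two triazoles only floors can be read, an at least 1.0-fold lower number from compound 3 to compound 4 (0.03 log units; that floor lies within the scatter) and an at least 1.0-fold lower number from compound 2 to compound 4 (0.03 log units; that floor lies within the scatter), so no difference can be claimed for 3-hydroxyphenyl in place of 2-fluorophenyl or 2-methylphenyl on an aromatic nitrogen: the limit of > 150000 nM in this assay, at which 2 of the 4 values shown sit.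

The compounds shown leave open whether the aromatic ring on the triazole matters at all, since the values here do not separate the kind of group on that ring from where it stands. They also leave open whether an amine or a carboxylic acid on that ring, or a longer chain in place of the saturated chain carbon, would give a number clearly apart from compound 1.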